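Bromine Removal Across Two Related Cores

The compounds below may be only part of what the source reports. "The series", "measured", "known", "first", "only" and "open" are said of these compounds alone.

Compound 1 `C=C1C[C@]23C[C@@]1(O)CC[C@@H]2c1cccc(C)c1[C@@H]3Cn1cc(-c2ccc(Br)cc2)nn1` was tested in a functional assay on SW480 cells (Homo sapiens) for cytotoxicity, read by MTT assay, with a stated time of 4 days (on this read-out lower numbers stand for stronger inhibition and higher numbers for weaker inhibition), where compound 1 gives only a limit, > 20000 nM. Compound 3 `C=C1C[C@]23C[C@@]1(O)CC[C@@H]2c1cccc(C)c1[C@@H]3Cn1cc(-c2ccccc2)nn1` carries the change (hydrogen in place of bromo on an aromatic carbon). In this assay compound 3 also sits at a limit, > 20000 nM. The step that the two limits leave unreadable from compound 1 to compound 3 therefore has no readable size, as the limit of > 20000 nM in this assay, at which 3 of the 3 values shown sit, records. Compound 2 `C=C1C[C@]23C[C@@]1(O)CC[C@H]2c1cc(Br)c(O)c(C)c1[C@@H]3Cn1cc(-c2ccc(F)cc2)nn1` rests on a different core, and the difference between the two cores is not broken down here. In this assay compound 2 again gives only a limit, > 20000 nM. Compound 4 `C=C1C[C@]23C[C@@]1(O)CC[C@H]2c1ccc(O)c(C)c1[C@@H]3Cn1cc(-c2ccc(F)cc2)nn1` has not yet been measured. It differs from compound 2 by hydrogen in place of bromo on an aromatic carbon, the same kind of change as that from compound 1 to compound 3, though the surroundings differ: in compound 2 the bromo sits ortho to a hydroxy group, meta to a fused ring and to a methyl group and para to a fused ring, whereas in compound 1 it is para to a large group. Because the limit of > 20000 nM in this assay, at which 3 of the 3 values shown sit, places all three measured values at the limit, the step that the limit leaves unreadable from compound 2 to compound 4 is expected to remain unreadable as well. Compound 4 is accordingly estimated at 30000 nM, most likely reported once more only as a limit.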

Compound 4, half-maximal inhibitory concentration: > 20000 nM
Compound 4 ended at the assay's limit; the forecaster's own chance of this, stated with the estimate: 80%; the middle value is on the limit's open side.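

In this assay compound 4 sits at a limit, as compound 2 does, so no step can be read from compound 2 to compound 4, nor between compound 1 and compound 3: the limit of > 20000 nM in this assay, at which 4 of the 4 values shown sit. The compounds shown leave open whether hydrogen in place of bromo changes cytotoxicity on either core, and how the two cores compare.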